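This account rests on a few compounds, and the source may have more. Where it says the series, first, only, none or still open, it means among the compounds named here.

Measured in an ADME assay on MDCK cells (Canis lupus familiaris) for cytotoxicity, read by MTT assay, with a stated time of 24 h; on this read-out lower numbers stand for higher toxicity in this test and higher numbers for lower toxicity in this test:
- Compound 1 `N#CCCN(Cc1cccs1)S(=O)(=O)c1ccc(F)cc1`: > 205000 nM
- Compound 2 `N#CCCN(Cc1cccs1)S(=O)(=O)c1ccc(Br)cc1`: > 173000 nM

Both entries are limits of the assay and not numbers. Compound 2 therefore has no exact position in this assay. Within the data shown here, its > 173000 nM is a limit, and the only other value available, that of compound 1, is a limit too.

The next compound, compound 3 `O=C(O)CCN(Cc1cccs1)S(=O)(=O)c1ccc(Br)cc1`, carries carboxy in place of cyano on a saturated chain carbon, two bonds along the chain from a sulfonamide nitrogen. Among the measured compounds shown here, the single measured step, a step that the two limits leave unreadable from compound 1 to compound 2, is bromo in place of fluoro on an aromatic carbon. For the measured compounds named here, it has no readable size and leaves the chain unchanged, so no measured step covers this replacement.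

The expectation rests only on compound 2, whose > 173000 nM is a limit. No direction can be derived from the data, so no step beyond the scatter is assumed. The expected change is an at least 1.0-fold lower number from compound 2 to compound 3 (0.02 log units; that floor lies within the scatter), and this figure is only an estimate. Compound 3 is expected at 165000 nM, with an estimated range of 80000 nM to 260000 nM, and may again be reported as a limit.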

Compound 3, half-maximal cytotoxic concentration: > 164000 nM
Compound 3: a limit, no number; the forecaster's own chance of this, stated with the estimate: 70%; the middle value lies beyond the limit too.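

In this assay compound 3 gives > 164000 nM, a limit and not a number. Among these compounds, compound 2 gives > 173000 nM, also a limit, so no step from compound 2 to compound 3 can be read. The compounds shown leave open whether carboxy in place of cyano on this chain shifts the half-maximal cytotoxic concentration at all, and in which direction.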